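Pyridin-3-yl in place of 4-fluorophenyl: stability notes

The source may report more compounds than this note shows. Statements on the series, on what has been measured and on what is new or still open speak of the compounds shown alone.

Measured in an ADME assay on microsomes from liver (Rattus norvegicus) for metabolic stability, with a stated time of 10 min, tested at 0.5 uM; on this read-out higher numbers stand for a more stable compound and lower numbers for a less stable compound:
- compound 1 `CCc1noc(C)c1[C@@H]1C[C@@](C)(c2ccc(F)cc2F)N=C(N)S1`: 59%
- compound 2 `Cc1onc(-c2ccc(F)cc2)c1[C@@H]1C[C@@](C)(c2ccc(F)cc2F)N=C(N)S1`: 35%

Compound 2 holds the lower of the two numbers, at 35%. Compound 3 `Cc1onc(-c2cccnc2)c1[C@@H]1C[C@@](C)(c2ccc(F)cc2F)N=C(N)S1` is the next to be read, and it differs from compound 2 on an aromatic carbon of a five-membered aromatic ring with 1 nitrogen and 1 oxygen: pyridin-3-yl in place of 4-fluorophenyl on an aromatic carbon. For the measured compounds named here, one measured step bears on this carbon, a number 24 percentage points lower from compound 1 to compound 2 (beyond the scatter). It involves ethyl rather than pyridin-3-yl, so it gives a scale for change here but no direction. Going by the values given here, no measured compound carries pyridin-3-yl. A modest rise in this assay is expected, smaller than that measured step, and a fall cannot be excluded. The expected change is a number 10 percentage points higher from compound 2 to compound 3 (within the scatter). For compound 3 the estimated value is 45%, with an expected range of 28% to 65%.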

Compound 3, percent of the compound remaining: 5%
The estimate for compound 3 lay 40 percentage points above the measured number, outside the stated range (below it).
By their numbers in this assay, from the lowest: compound 3; then compound 2; then compound 1.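

In this assay, this aromatic carbon, next to the ring nitrogen, responds not only to ethyl being replaced but also to a change between two six-membered aromatic rings: a number 30 percentage points lower from compound 2 to compound 3 (beyond the scatter) comes with pyridin-3-yl in place of 4-fluorophenyl. Measured against ethyl, a number 54 percentage points lower from compound 1 to compound 3 (beyond the scatter) goes with pyridin-3-yl, a larger step than a number 24 percentage points lower from compound 1 to compound 2 (beyond the scatter) with 4-fluorophenyl, so the two rings do not read alike here and the ring with 1 hetero atom stands lowest of the three. Nothing measured on these compounds accounts for the fall.

Still open, as far as these compounds go, is whether plain phenyl at this carbon would read nearer compound 2 or compound 3, which would separate the loss of fluorine from the entry of the ring nitrogen. Pyridin-4-yl, pyridin-2-yl and a saturated amine such as morpholine at the same carbon also remain open.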